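Vero cytotoxicity: amide replacing urea on the shared core

The compounds below may be only part of what the source reports. "The series", "measured", "known", "first", "only" and "open" are said of these compounds alone.

Measured so far:
compound 1 `CCCCNC(=O)Nc1cc2nc(C3CCCCC3)[nH]c2cc1N(CC)CC`: > 100 ug/mL (a limit of the assay)
compound 2 `CN(C)c1cc2[nH]c(C3CCCCC3)nc2cc1NC(=O)c1cccs1`: > 100 ug/mL (a limit of the assay)

In an ADME assay on Vero cells (Chlorocebus sabaeus) for cytotoxicity, read by resazurin assay, with a stated time of 3 days (on this read-out lower numbers stand for stronger inhibition and higher numbers for weaker inhibition), compound 1 gives > 100 ug/mL, a limit and not a number. Compound 2 likewise gives > 100 ug/mL, again a limit. Compound 1 thus stands at the limit of > 100 ug/mL in this assay, at which 2 of the 2 values shown sit, so no ordering among the measured compounds can be drawn. Compound 3 `CCN(CC)c1cc2[nH]c(C3CCCCC3)nc2cc1NC(=O)c1ccc(Br)cc1` carries 4-bromophenyl in place of butylamino on a carbonyl carbon. With both measured values at the limit, the step from compound 1 to compound 3 is expected to be none beyond the scatter, a step that the limit leaves unreadable from compound 1 to compound 3. Compound 3 is estimated at 110 ug/mL in this assay, between 35 ug/mL and 300 ug/mL, most likely reported only as a limit.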

Compound 3, half-maximal inhibitory concentration: > 100 ug/mL
Compound 3 ended at the assay's limit; the forecaster's own chance of this, stated with the estimate: 70%; the middle value lies beyond the limit too.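

No step can be read from compound 1 to compound 3, as both values are limits of the assay: the limit of > 100 ug/mL in this assay, at which 3 of the 3 values shown sit.

The compounds shown leave open whether 4-bromophenyl in place of butylamino on a carbonyl carbon has any effect in this assay.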